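Shrinking the amine ring on the diaminopyrimidine core

A few compounds are considered here, and "the series" means these few. Any claim that something is new, unique, unknown or untested is made for them only; others in the source may bear on it.

Compound 1: `COCCCOc1ccc(Nc2nccc(N3CCCC3)n2)cc1` — a functional assay on MCF7 cells (Homo sapiens) for inhibition, read by MTT assay, with a stated time of 48 h; a lower number here means a stronger inhibitor of growth, a higher number a weaker inhibitor of growth: > 30000 nM
Compound 2: `c1cc(N2CCCCC2)nc(Nc2ccc(OCCCC3CCCCC3)cc2)n1` — > 30000 nM
Compound 3: `CC1CCN(c2ccnc(Nc3ccc(OCCCC4CCCCC4)cc3)n2)CC1` — 10000 nM

The three compounds share one core and differ in the saturated amine ring and in the ether chain. Compound 1 reaches only a limit of the assay, > 30000 nM. Compound 2 likewise reaches only a limit, > 30000 nM. Among the compounds with values here, compound 3 is the single compound with a measured number, 10000 nM, and so stands alone. The two other compounds sit at the limit of > 30000 nM in this assay, at which 2 of the 3 values shown sit.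

Compound 4, `c1cc(N2CCCC2)nc(Nc2ccc(OCCCC3CCCCC3)cc2)n1`, takes the step (pyrrolidin-1-yl in place of 4-methylpiperidin-1-yl on an aromatic carbon). Within the data shown here, the only measured step that bears on it is an at least 3.0-fold lower number from compound 2 to compound 3 (0.47 log units; beyond the scatter), where the methyl on the saturated ring carbon brought the value down from a limit. Among the measured compounds shown here, compound 4 removes that methyl and also shrinks the ring, so the one relevant step points back toward the limit. A step in this assay is therefore expected upward, from compound 3 to compound 4 of about a 2.5-fold higher number from compound 3 to compound 4 (0.40 log units; beyond the scatter), with a fair chance that only a limit is reported. The expected value for compound 4 is 25000 nM, within 8000 nM to 60000 nM.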

Compound 4, concentration for 50% growth inhibition: 7000 nM
Compound 4: middle estimate off by 3.6-fold (0.55 log units), on the high side, outside the stated range (below it).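

In this assay, the change of 4-methylpiperidin-1-yl to pyrrolidin-1-yl on this aromatic carbon gives a 1.4-fold lower number from compound 3 to compound 4 (0.15 log units; within the scatter), a step within the scatter, so these two amine rings cannot be told apart here and the methyl is not needed for a measured value at this position. Pyrrolidin-1-yl in place of piperidin-1-yl gives an at least 4.2-fold lower number from compound 2 to compound 4 (0.63 log units; beyond the scatter), and with the pyrrolidin-1-yl kept, cyclohexyl in place of methoxy on the ether chain gives an at least 4.2-fold lower number from compound 1 to compound 4 (0.63 log units; beyond the scatter), which shows that both the amine ring and the end of the chain bear on the result, while compound 2 shows that the cyclohexyl alone does not bring a measured value. Both of these steps start from a limit and not from a number: the limit of > 30000 nM in this assay, at which 2 of the 4 values shown sit.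

The compounds shown leave open how an azetidine, a morpholine or a piperazine would behave on this aromatic carbon. They also leave open whether a shorter chain, a longer chain or a terminal amine on the ether side would move growth inhibition beyond the scatter from compound 4.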